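Trimming a Methyl from the Sulfur Chain of Compound 3

A few compounds are considered here, and "the series" means these few. Any claim that something is new, unique, unknown or untested is made for them only; others in the source may bear on it.

In a functional assay on MES-SA cells (Homo sapiens) for inhibition (on this read-out lower numbers stand for stronger inhibition and higher numbers for weaker inhibition), compound 1 `CC1=C(SCCCO)C(=O)c2ccccc2C1=O` gives > 10000 nM, which is a limit of the assay. Compound 2 `CC1=C(SCCCCO)C(=O)c2ccccc2C1=O` likewise gives > 10000 nM, again a limit. Compound 3 `CC1=C(SC(C)C(C)O)C(=O)c2ccccc2C1=O` also sits at a limit, > 10000 nM. Compound 3 therefore stands nowhere more precisely than at the limit shared by all three measured compounds (the limit of > 10000 nM in this assay, at which 3 of the 3 values shown sit). Compound 4 `CC1=C(SCC(C)O)C(=O)c2ccccc2C1=O` differs from compound 3 by hydrogen in place of methyl on a saturated chain carbon bound to a saturated chain carbon and a sulfur. Within the data shown here, the steps that bear on this change, a step that the two limits leave unreadable from compound 1 to compound 2, a step that the two limits leave unreadable from compound 1 to compound 3 and a step that the two limits leave unreadable from compound 2 to compound 3, are all unreadable, so no size can be read for alterations of the chain on sulfur. The chemist therefore expects no step beyond the scatter, the estimated step that the limit leaves unreadable from compound 3 to compound 4 most likely ending again at a limit. For compound 4 the chemist estimates 20000 nM, within 5000 nM to 100000 nM.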

Compound 4, half-maximal inhibitory concentration: 5100 nM
Estimate against measurement, compound 4: 3.9-fold (0.59 log units) above; measured number inside the range.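

Among these compounds, compound 4, bearing (2-hydroxypropyl)sulfanyl, is the first compound here to give a number rather than a limit, so this position can yield a readable value: the limit of > 10000 nM in this assay, at which 3 of the 4 values shown sit.
Hydrogen in place of methyl gives an at least 1.9-fold lower number from compound 3 to compound 4 (0.29 log units; that floor lies within the scatter), and the two chain changes give an at least 1.9-fold lower number from compound 2 to compound 4 (0.29 log units; that floor lies within the scatter) and an at least 1.9-fold lower number from compound 1 to compound 4 (0.29 log units; that floor lies within the scatter).
Going by these compounds, each of these is only a floor, so the true size of each step stays unknown.

The compounds shown leave open whether an amine or a carboxylic acid in place of the hydroxy would keep a readable value. They also leave open what a longer chain carrying the same branched hydroxy would do.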